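Swapping Methyl for Fluoro in Two Inactive Compounds

This account rests on a few compounds, and the source may have more. Where it says the series, first, only, none or still open, it means among the compounds named here.

Compound 1 `C/C(=C\c1cc(-c2ccc(C)cc2)co1)C(N)=O`: > 50000 nM
Compound 2 `C/C(=C\c1ccc(-c2ccc(C)cc2)o1)C(N)=O`: > 50000 nM

Both compounds were tested in a functional assay on A549 cells (Homo sapiens) for cytotoxicity, read by CCK-8 assay, with a stated time of 24 h; on this read-out lower numbers stand for stronger inhibition and higher numbers for weaker inhibition. For compound 1 the value > 50000 nM is a limit of this assay, not a number. Compound 2 likewise reaches only the limit > 50000 nM. Compound 2 therefore stands at the limit of > 50000 nM in this assay, at which 2 of the 2 values shown sit, so no difference between the two compounds is visible. Compound 3 `C/C(=C\c1ccc(-c2ccc(F)cc2)o1)C(N)=O` carries fluoro in place of methyl on an aromatic carbon. With both known values sitting at the limit, the step that the limit leaves unreadable from compound 2 to compound 3 is expected to stay within the scatter. For compound 3 the expected value is 60000 nM, with a range from 20000 nM to 200000 nM, most likely again reported only as a limit.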

Compound 3, half-maximal inhibitory concentration: 1650 nM
Estimate against measurement, compound 3: 36-fold (1.56 log units) above, outside the stated range (below it).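

In this assay, the group on this aromatic carbon, para to a large group, proves decisive: fluoro in place of methyl gives an at least 30-fold lower number from compound 2 to compound 3 (1.48 log units; beyond the scatter). Within the data shown here, compound 3 is the first compound here with a readable number, so a change of one heavy atom is enough to bring out cytotoxicity. The true size of the step stays unknown because compound 2 gives only a limit: the limit of > 50000 nM in this assay, at which 2 of the 3 values shown sit.

On these data alone, whether chloro, methoxy or a plain hydrogen at this place would give a similar number stays open. So does whether fluoro would have the same effect on the core of compound 1.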